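Swapping the Aryl Tail on a Sulfonamide Core

A few compounds are considered here, and "the series" means these few. Any claim that something is new, unique, unknown or untested is made for them only; others in the source may bear on it.

Compound 1 `CC1CCN(C2CCN(S(=O)(=O)c3ccc(-c4ccccc4F)cc3)CC2)CC1` gives 5 nM in a functional assay on DLD-1 cells (Homo sapiens) for antiproliferative activity, read by CellTiter-Glo, with a stated time of 72 h; a lower number here means a stronger inhibitor, a higher number a weaker inhibitor.
Compound 2 `Cc1ccc(-c2cccc(S(=O)(=O)N3CCC(N4CCC(C)CC4)CC3)c2)cc1` gives 11 nM in this assay.

Compound 1 stands at the lower of the two numbers, and its step to compound 2 lies beyond the usual scatter of this kind of measurement. A third compound, compound 3 `COc1ccc(-c2ccc(S(=O)(=O)N3CCC(N4CCC(C)CC4)CC3)cc2)cc1`, has not yet been measured. Relative to compound 1, it carries 4-methoxyphenyl in place of 2-fluorophenyl on an aromatic carbon. Within the data shown here, no pair of measured compounds differs in exactly this way, so no measured step shows how this change plays out. Both measured compounds are strong inhibitors carrying different aryl groups on the shared core, which hints that the core tolerates such swaps. The step is expected to be small, a 2.0-fold higher number from compound 1 to compound 3 (0.30 log units; within the scatter), amounting at most to a mild loss. Compound 3 is therefore estimated at 10 nM, with a range from 3 nM to 35 nM.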

Compound 3, half-maximal inhibitory concentration: 263 nM
For compound 3 the middle estimate is 26-fold (1.42 log units) below the measured one; measured number above the stated range.
By their numbers in this assay, from the lowest: compound 1; then compound 2; then compound 3.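

In this assay, putting 4-methoxyphenyl in place of 2-fluorophenyl on this aromatic carbon brings a 53-fold higher number from compound 1 to compound 3 (1.72 log units; beyond the scatter), a large loss from one change to the group attached to the core of compound 1. This position is therefore far less forgiving than the two earlier values alone could show: the identity of the aryl group can strongly affect activity here. No separate measurement bears on why this happens, so the cause remains unknown.

This step replaces the fluorine and adds the methoxy group at once, so it cannot show whether losing one or gaining the other matters more. A plain phenyl group at this position would help separate the two, and a chlorine-bearing phenyl would show how other ring substituents fare.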